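Amino in Place of Fluoro: An Expected Limit

The source may hold more compounds than are shown below. What is called first, only, known or untested is meant among the compounds shown, and "the series" means these compounds.

Compound 1 `Fc1ccc(Nc2nc(-c3cccc(F)c3)nc3ccc(F)cc23)cc1` gives > 50000 nM in a functional assay on HL-60 cells (Homo sapiens) for cytotoxicity, read by MTT assay, with a stated time of 48 h (on this read-out lower numbers stand for stronger inhibition and higher numbers for weaker inhibition), which is a limit of the assay rather than a number. Compound 2 `Fc1cccc(-c2nc(Nc3ccccc3Cl)c3cc(F)ccc3n2)c1` likewise gives > 50000 nM, again a limit. Compound 3 `Oc1cccc(Nc2nc(-c3cccc(F)c3)nc3ccc(F)cc23)c1` gives > 50000 nM, also a limit. Among the compounds with values here, the steps a step that the two limits leave unreadable from compound 1 to compound 2, a step that the two limits leave unreadable from compound 1 to compound 3 and a step that the two limits leave unreadable from compound 2 to compound 3 therefore cannot be sized, and the only evidence is the limit of > 50000 nM in this assay, at which 3 of the 3 values shown sit.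

Compound 4 `Nc1ccc(Nc2nc(-c3cccc(F)c3)nc3ccc(F)cc23)cc1` differs from compound 1 by amino in place of fluoro on an aromatic carbon. Within the data shown here, no measured step bears on this exchange, and every measured value is a limit, so neither a direction nor a size can be read. Compound 4 is therefore expected to remain near that limit, with an estimated 50000 nM in a range from 15000 nM to 150000 nM. The expected step is then a number no higher from compound 1 to compound 4 (the limit leaves the size open).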

Compound 4, half-maximal inhibitory concentration: > 50000 nM
Compound 4: a limit, no number; the forecaster's own chance of this, stated with the estimate: 70%; the middle value sits exactly at the limit.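

Within the data shown here, compound 4 ends at a limit, as do compound 1, compound 2 and compound 3, so no step to compound 4 can be read. How strongly any of these four compounds acts remains open, with only this to go on: the limit of > 50000 nM in this assay, at which 4 of the 4 values shown sit.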